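Furan for thiophene on a shared nucleoside core

The source may hold more compounds than are shown below. What is called first, only, known or untested is meant among the compounds shown, and "the series" means these compounds.

Three nucleoside analogues share one core and differ only in two groups. Compound 3 `Cc1ncnc2c1c(-c1ccsc1)cn2[C@@H]1O[C@H](CO)[C@@H](O)[C@H]1O` carries a thiophen-3-yl group and a methyl group, compound 1 `Cc1ncnc2c1c(-c1ccoc1)cn2[C@@H]1O[C@H](CO)[C@@H](O)[C@H]1O` carries a furan-3-yl group in its place, and compound 2 `CNc1ncnc2c1c(-c1ccsc1)cn2[C@@H]1O[C@H](CO)[C@@H](O)[C@H]1O` keeps the thiophen-3-yl group while a methylamino group replaces the methyl; the difference between the two cores is methylamino in place of methyl on an aromatic carbon. In a functional assay on A549 cells (Homo sapiens), read by MTT assay, with a stated time of 72 h (on this read-out higher numbers stand for weaker inhibition and lower numbers for stronger inhibition), compound 3 gives > 20000 nM, a limit of the assay. In this assay compound 1 gives > 20000 nM, also a limit. In this assay compound 2 gives > 20000 nM, again a limit. Hence a step that the two limits leave unreadable from compound 3 to compound 1 and a step that the two limits leave unreadable from compound 2 to compound 3, both resting on (the limit of > 20000 nM in this assay, at which 3 of the 3 values shown sit).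

Compound 4 `CNc1ncnc2c1c(-c1ccoc1)cn2[C@@H]1O[C@H](CO)[C@@H](O)[C@H]1O` has not been measured in this assay. It differs from compound 2 by furan-3-yl in place of thiophen-3-yl on an aromatic carbon, the same change as furan-3-yl in place of thiophen-3-yl on an aromatic carbon, made on the core of compound 2 instead of compound 3. Since that earlier step could not be sized, he expects a step that the limit leaves unreadable from compound 2 to compound 4 to stay unreadable as well. He estimates compound 4 in this assay at 30000 nM, within 12000 nM and 100000 nM.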

Compound 4, half-maximal inhibitory concentration: > 20000 nM
Compound 4 gave a limit, no number; the forecaster's own chance of this, stated with the estimate: 85%; the middle value lies beyond the limit too.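

In this assay compound 4 gives > 20000 nM, a limit of the assay, so neither its step from compound 2 nor its step from compound 1 can be read: the limit of > 20000 nM in this assay, at which 4 of the 4 values shown sit.

The compounds shown leave open how furan-3-yl compares with thiophen-3-yl, and methylamino with methyl, on the shared core, as none of the four gives a number.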